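Methoxy for Methyl Carried onto a Second Core

The source may hold more compounds than are shown below. What is called first, only, known or untested is meant among the compounds shown, and "the series" means these compounds.

Compound 1 `Cc1ccc(S(=O)(=O)c2n[nH]c3ccc(N4CCN(C)CC4)cc23)cc1` and compound 3 `COc1ccc(S(=O)(=O)c2n[nH]c3ccc(N4CCN(C)CC4)cc23)cc1` share one core and differ at a single position. In an assay on HeLa cells for displacement of a labelled ligand from 5-hydroxytryptamine receptor 6 (Homo sapiens) (on this read-out higher numbers stand for weaker inhibition and lower numbers for stronger inhibition), compound 1 gives 4.9 nM, and compound 3 gives 12 nM. The change that separates them is methoxy in place of methyl on an aromatic carbon, and it brings a 2.4-fold higher number from compound 1 to compound 3 (0.39 log units; beyond the scatter).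

Compound 2 `Cc1ccc(S(=O)(=O)c2n[nH]c3cccc(N4CCNCC4)c23)cc1` sits on a different core; the difference between the two cores is not broken down here. In this assay compound 2 gives 134 nM, the highest number of the three measured compounds. Compound 4 `COc1ccc(S(=O)(=O)c2n[nH]c3cccc(N4CCNCC4)c23)cc1` has not yet been measured. It carries the change (methoxy in place of methyl on an aromatic carbon), which is the same change already seen from compound 1 to compound 3, since the place where it is made is described in the same words in both pairs.

Going by the values given here, only one earlier instance of this change exists in the set, so the expectation for compound 4 rests entirely on it. Compound 4 is expected to show a step of a 2.4-fold higher number from compound 2 to compound 4 (0.38 log units; beyond the scatter), a size chosen to match what was seen because of a 2.4-fold higher number from compound 1 to compound 3 (0.39 log units; beyond the scatter). Starting from the value of compound 2 of 134 nM, compound 4 is therefore estimated at 320 nM in this assay, with a plausible span from 130 nM to 800 nM given the single precedent and the wide gap between the two cores.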

Compound 4, inhibition constant: 88 nM
Compound 4: middle estimate off by 3.6-fold (0.56 log units), on the high side; the measured number lies below the stated range.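

On the core of compound 2, methoxy in place of methyl brings a 1.5-fold lower number from compound 2 to compound 4 (0.18 log units; within the scatter) in this assay, so on this core the change leaves the number within the usual scatter of the measurement. The same change therefore does not carry from one core to the other as a fixed step, and the two steps cannot be treated as one shared value: the same change on two cores in this assay, a 2.4-fold higher number (0.39 log units; beyond the scatter) from compound 1 to compound 3 and a 1.5-fold lower number (0.18 log units; within the scatter) from compound 2 to compound 4, 3.7-fold (0.57 log units) apart, beyond the scatter of two such steps This shows that, in this series, the step seen on the core of compound 1 cannot be transferred to the core of compound 2, but it rests on one pair per core and does not show which difference between the two cores goes with the difference between the steps.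

The compounds shown hold only methyl and methoxy at this place, para to a large group, so it remains open how an ethoxy group, a chlorine or a trifluoromethyl would read on either core. As far as these compounds go, it also remains open whether the change would, on a third core, resemble the step from compound 1 to compound 3, the step from compound 2 to compound 4, or neither.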